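The compounds below may be only part of what the source reports. "The series", "measured", "known", "first", "only" and "open" are said of these compounds alone.

Measured so far:
- compound 1, `COc1cc(Nc2nc3cccc(-c4ccccc4OC(F)(F)F)c3o2)cc(OC)c1OC`, gives 4000 nM
- compound 2, `COc1ccc(F)cc1-c1cccc2nc(Nc3cc(OC)c(OC)c(OC)c3)oc12`, gives 40 nM

These two compounds were tested in an assay on isolated protein for inhibition of ribosomal protein S6 kinase alpha-2 (Homo sapiens), with a stated time of 150 min; a higher number here means a weaker inhibitor, a lower number a stronger inhibitor. Going by the values given here, compound 2 holds the lowest of the two numbers, and the only neighbour is compound 1, which sits a 100-fold lower number from compound 1 to compound 2 (2.00 log units; beyond the scatter) away in the other direction. That single step was large, and it came from exchanging one aromatic group on the shared core for another while everything else stayed the same.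

Compound 3, `COc1cc(Nc2nc3cccc(-c4cccc5cn[nH]c45)c3o2)cc(OC)c1OC`, has not yet been measured. It differs from compound 2 in the same position: 1H-indazol-7-yl in place of 5-fluoro-2-methoxyphenyl on an aromatic carbon. Among the compounds with values here, the only measured step that bears on this change is the one from compound 1 to compound 2, which shows that this part of the molecule can move the number a great deal. Within the data shown here, there is no measured step that tells how an indazolyl group in particular behaves here, so the direction is uncertain. A moderate move is expected, and the step from compound 2 to compound 3 is estimated at a 2.5-fold higher number from compound 2 to compound 3 (0.40 log units; beyond the scatter). Compound 3 is therefore expected to give about 100 nM, with a likely range from 10 nM to 1000 nM.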

Compound 3, half-maximal inhibitory concentration: 50 nM
Beside the measured number, compound 3's estimate is 2.0-fold (0.30 log units) above it; low and high end bracket the measured number.
By their numbers in this assay, from the lowest: compounds 2 and 3 (each within the scatter of the next); then compound 1.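

In this assay, the move from 5-fluoro-2-methoxyphenyl to 1H-indazol-7-yl gives a 1.3-fold higher number from compound 2 to compound 3 (0.10 log units; within the scatter), so these two groups cannot be told apart at this position, even though one is a single carbon-only ring and the other adds a five-membered ring with a hydrogen-bond donor. Measured against 2-(trifluoromethoxy)phenyl, the 1H-indazol-7-yl group gives an 80-fold lower number from compound 1 to compound 3 (1.90 log units; beyond the scatter), which means the large gain seen earlier is not tied to one particular group, since two different groups at this aromatic carbon now stand far from compound 1. Nothing measured on these compounds explains why these two groups read alike or why compound 1 stands apart.

The compounds shown leave open whether the hydrogen on the indazole ring nitrogen matters at all, and whether the fluorine or the methoxy group of compound 2 matters on its own, since no compound here changes only one of these features. As far as these compounds go, how this position would respond to a plain phenyl ring, or to a ring carrying an amine or a carboxylic acid, also remains unknown from these three compounds.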